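The source may hold more compounds than are shown below. What is called first, only, known or untested is meant among the compounds shown, and "the series" means these compounds.

Working notes on the series. The shared core of compound 1 `c1ccc(C2Cc3nccn3C2)cc1` carries the aromatic ring without a substituent; in a functional assay on CHO cells for agonist activity at Alpha-1A adrenergic receptor (Homo sapiens), read by FLIPR and calcium flux (on this read-out lower numbers stand for smaller maximal responses and higher numbers for larger maximal responses), compound 1 gives 80%; 74%; 25%; 85% (4 entries), and the spread across those repeats, (the several entries of compound 1 in this assay, 80%; 74%; 25%; 85% (4 entries)), is wide enough that no single number can be drawn from them. Compound 2 `FC(F)Oc1ccccc1C1Cc2nccn2C1` carries difluoromethoxy on the aromatic ring; in this assay compound 2 gives 75%. Compound 3 `COc1ccccc1C1CCc2nc[nH]c2C1`, built on a different core, gives 95% in this assay. Of the two single numbers compound 2 therefore stands lowest, with compound 3 above it by a gap beyond the scatter, while compound 1 adds only its scattered repeats.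

Compound 4 `Clc1ccccc1C1Cc2nccn2C1` is not yet measured. Against compound 2 the difference is chloro in place of difluoromethoxy on an aromatic carbon. For the measured compounds named here, no measured pair in the set follows this change, so the step has to be guessed: the expectation is a step near zero, within the scatter, which is what a number 2 percentage points higher from compound 2 to compound 4 (within the scatter) amounts to. In this assay compound 4 is estimated at 77%, expected to fall between 50% and 95%.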

Compound 4, largest response reached (Emax), in percent of the reference or control that the assay uses: 56%
Compound 4: the middle estimate sits 21 percentage points above what was measured; the range from low to high includes it.
By their numbers in this assay, from the lowest: compound 4; then compound 2; then compound 3.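

For the compounds shown here, at this place on the aromatic ring, ortho to a group of 8 heavy atoms, chloro in place of difluoromethoxy gives a number 19 percentage points lower from compound 2 to compound 4 (beyond the scatter), the first step between compounds that differ in one place, and it shows that the maximal response in this assay depends on the group held here. The change swaps 4 heavy atoms with 1 hydrogen-bond acceptor for 1 heavy atom with no hydrogen-bond acceptor, and this single pair cannot separate those differences. Neither group can be placed against the ring without a substituent, as compound 1 offers no single number: the several entries of compound 1 in this assay, 80%; 74%; 25%; 85% (4 entries)

Going by these compounds, whether a nitrile or an amine on this carbon would give a response nearer compound 2 or compound 4 remains open. Also open, on these data alone, is whether the same change would give a step of similar size on the core of compound 3.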